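The source may report more compounds than this note shows. Statements on the series, on what has been measured and on what is new or still open speak of the compounds shown alone.

Compound 2 `Cc1cc(Nc2ccc(S(F)(F)(F)(F)F)cc2)n2nc(C(F)(F)F)nc2n1` carries a trifluoromethyl group on the shared core. In an in vitro ADME assay on microsomes from liver (Mus musculus) for metabolic stability (on this read-out lower numbers stand for slow clearance and higher numbers for fast clearance), compound 2 gives < 6 mL.min-1.g-1, which is a limit of the assay rather than a measured number, so only a range is known for where it stands. Compound 1 `COCc1nc2nc(C)cc(Nc3ccc(S(F)(F)(F)(F)F)cc3)n2n1` differs from it in one place, and in this assay compound 1 gives 14.3 mL.min-1.g-1. Among the measured compounds shown here, the only measured step is an at least 2.3-fold lower number from compound 1 to compound 2 (0.37 log units; beyond the scatter), and it runs into the limit (the limit of < 6 mL.min-1.g-1 in this assay, at which 1 of the 2 values shown sits), so its true size is not known. Compound 3 `COCCc1nc2nc(C)cc(Nc3ccc(S(F)(F)(F)(F)F)cc3)n2n1` has not yet been measured. The change is 2-methoxyethyl in place of trifluoromethyl on an aromatic carbon. It brings back an ether-bearing side chain close to that of compound 1, so the earlier step should be largely reversed. Compound 3 is expected to show an at least 3.0-fold higher number from compound 2 to compound 3 (0.47 log units; beyond the scatter). The estimate for compound 3 is 18 mL.min-1.g-1, with a range from 8 mL.min-1.g-1 to 40 mL.min-1.g-1.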

Compound 3, intrinsic clearance in microsomes in the liver assay: 14.1 mL.min-1.g-1
Compound 3: the middle estimate sits 1.3-fold (0.11 log units) above what was measured; the measured number falls inside the stated range.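

In the liver assay, the exact ether side chain at this position makes little difference, since 2-methoxyethyl and methoxymethyl give a 1.0-fold lower number from compound 1 to compound 3 (0.01 log units; within the scatter), while replacing trifluoromethyl with 2-methoxyethyl gives an at least 2.3-fold higher number from compound 2 to compound 3 (0.37 log units; beyond the scatter). The value of compound 2 there, < 6 mL.min-1.g-1, is a limit of the assay. In a physicochemical assay for lipophilicity, at pH 7.4 (on this read-out lower numbers stand for lower lipophilicity and higher numbers for higher lipophilicity), compound 2 gives 3.7 and compound 3 gives 3, a number 0.70 log units lower from compound 2 to compound 3 (beyond the scatter), so for this pair the two read-outs move in opposite directions.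

From the compounds shown here alone, the true size of the step away from trifluoromethyl stays unknown. Also open, going by these compounds, is whether a plain propyl chain, which has no oxygen, or an amine at this position would read like the ether side chains or like trifluoromethyl in the liver assay.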